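Removing the tert-butoxycarbonyl Group from a Spiro Hydantoin Amide

This account rests on a few compounds, and the source may have more. Where it says the series, first, only, none or still open, it means among the compounds named here.

The series shares one core, carried by compound 1 `CC(C)(C)OC(=O)NCCCCNC(=O)CN1CN(c2ccccc2)C2(CCN(C(=O)c3ccc(C4CCCCC4)cc3)CC2)C1=O` and compound 3 `CC(C)(C)OC(=O)NC1CCN(C(=O)CN2CN(c3ccccc3)C3(CCN(C(=O)c4ccc(C5CCCCC5)cc4)CC3)C2=O)CC1`, both with a cyclohexylphenyl amide. In an assay on HEK293 cells for displacement of a labelled ligand from NPC1-like intracellular cholesterol transporter 1 (Homo sapiens) (a higher number here means a weaker inhibitor, a lower number a stronger inhibitor), compound 1 gives 4600 nM, and compound 3 gives 4800 nM, two values that sit within the usual scatter of each other. Compound 2 `CC(C)(C)OC(=O)NCCCCNC(=O)CN1CN(c2ccccc2)C2(CCN(C(=O)c3ccc(C(C)(C)C)cc3)CC2)C1=O` carries a tert-butylphenyl amide instead; in this assay compound 2 gives "not determined" (no result reported), so it has no place on these values. Compound 4 `CC(C)(C)c1ccc(C(=O)N2CCC3(CC2)C(=O)N(CC(=O)NCCCCN)CN3c2ccccc2)cc1` differs from compound 2 in one place (hydrogen in place of tert-butoxycarbonyl on an amine nitrogen). For the measured compounds named here, no measured pair shows this change, so the step is expected to be small, in no certain direction, and likely within the scatter. Compound 4 is estimated at 5000 nM, between 1500 nM and 17000 nM.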

Compound 4, half-maximal inhibitory concentration: 14500 nM
Compound 4: middle estimate off by 2.9-fold (0.46 log units), on the low side, within the range that was stated.
By their numbers in this assay, from the lowest: compounds 1 and 3 (each within the scatter of the next); then compound 4.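

In this assay compound 4 gives 14500 nM while compound 2 gives "not determined" (no result reported) so no step can be read between them. As far as these compounds go, what replacing tert-butoxycarbonyl with hydrogen does to binding stays open. Nothing available explains the value of compound 4.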